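A few compounds are considered here, and "the series" means these few. Any claim that something is new, unique, unknown or untested is made for them only; others in the source may bear on it.

Compound 1 `C=C1C[C@]23C[C@@]1(O)CC[C@@H]2c1cccc(C)c1[C@@H]3Cn1cc(-c2ccc(C)cc2)nn1` was examined in a functional assay on HL-60 cells (Homo sapiens) for cytotoxicity, read by MTT assay, with a stated time of 4 days; a higher number here means a weaker inhibitor, a lower number a stronger inhibitor. In this assay compound 1 gives > 20000 nM, which is a limit of the assay rather than a measured number. Compound 2 `C=C1C[C@]23C[C@@]1(O)CC[C@H]2c1ccc(OS(=O)(=O)c2ccc(C)cc2)c(C)c1[C@@H]3Cn1cc(-c2ccc(F)cc2)nn1` likewise gives > 20000 nM in this assay, again a limit. Going by the values given here, both values therefore sit at the same point, (the limit of > 20000 nM in this assay, at which 2 of the 2 values shown sit), so the two compounds cannot be told apart on these numbers, and no step between measured compounds is available. Compound 3 `C=C1C[C@]23C[C@@]1(O)CC[C@@H]2c1cccc(C)c1[C@@H]3Cn1cc(-c2ccc(C(F)(F)F)cc2)nn1` differs from compound 1 in a single place: trifluoromethyl in place of methyl on an aromatic carbon. Because compound 1 stands at the limit > 20000 nM, no direction for this change can be read from the data, and a step no larger than the scatter is expected, with compound 3 most likely again reported only as a limit. The step that the limit leaves unreadable from compound 1 to compound 3 is the expected outcome. The estimate for compound 3 in this assay is 30000 nM, between 8000 nM and 100000 nM.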

Compound 3, half-maximal inhibitory concentration: > 20000 nM
Compound 3: no number, only a limit; the forecaster's own chance of this, stated with the estimate: 80%; the middle value is on the limit's open side.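

In this assay compound 3 gives > 20000 nM, again a limit, so no step can be read between compound 1 and compound 3: the limit of > 20000 nM in this assay, at which 3 of the 3 values shown sit.

The compounds shown leave open how trifluoromethyl and methyl compare here, and whether any compound with this shared core reaches a measurable value in this assay.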